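This account rests on a few compounds, and the source may have more. Where it says the series, first, only, none or still open, it means among the compounds named here.

In a physicochemical assay for solubility, in phosphate buffer, measured as kinetic solubility, at pH 7.4 (on this read-out higher numbers stand for higher solubility and lower numbers for lower solubility), compound 1 (`O[C@@H](CCc1ccc(F)cc1)C[C@@H](O)c1cc(-c2ccccc2)on1`) gives 25000 nM. Among the compounds with values here, compound 2 (`COc1ccc(CC[C@H](O)C[C@@H](O)c2cc(-c3ccccc3)on2)cc1`) gives 25000 nM, level with compound 1 at the digits reported, and compound 1 is its only measured neighbour.

Compound 3 (`COc1cccc(CC[C@H](O)C[C@@H](O)c2cc(-c3ccccc3)on2)c1`) has not yet been measured. It has the same atoms as compound 2, joined differently: 3-methoxyphenyl in place of 4-methoxyphenyl on a saturated chain carbon, three bonds along the chain from an oxygen on a saturated carbon. The change is 3-methoxyphenyl in place of 4-methoxyphenyl on a saturated chain carbon, three bonds along the chain from an oxygen on a saturated carbon.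

Within the data shown here, one measured step bears on this, and only indirectly: no change at the digits printed from compound 1 to compound 2 (within the scatter), with methoxy in place of fluoro on an aromatic carbon. Among the measured compounds shown here, that step exchanged one group for another, and no measured pair shows the methoxy group changing place, so the evidence is thin. Given the absence of any measurable shift in that single step, no change beyond the scatter is expected, in either direction. The estimated step is no change at the digits printed from compound 2 to compound 3 (within the scatter). In this assay the estimate for compound 3 is 25000 nM, with an expected range from 14000 nM to 35000 nM.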

Compound 3, solubility: 25000 nM
Beside the measured number, compound 3's estimate shows no gap at the digits printed; low and high end bracket the measured number.
By their numbers in this assay, from the lowest: compounds 1, 2 and 3 (each within the scatter of the next).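

In this assay, within the data shown here, moving the methoxy group on the aromatic ring gives no change at the digits printed from compound 2 to compound 3 (within the scatter) and supplies the first measured pair in which a group changes place rather than being exchanged for another. The change is 3-methoxyphenyl in place of 4-methoxyphenyl on a saturated chain carbon, three bonds along the chain from an oxygen on a saturated carbon. Read against the fluoro compound, the same place gives no change at the digits printed from compound 1 to compound 3 (within the scatter) and so, among the three compounds, 4-fluorophenyl, 4-methoxyphenyl and 3-methoxyphenyl at this place are not told apart by this assay while no measurement at hand offers a reason for this result.

Open, from the compounds shown here alone, is whether this level read-out would hold with a group of another kind on the aromatic ring, such as an amine or a carboxylic acid in place of the methoxy. Also open, going by these compounds, is whether a longer chain at this place, or a change elsewhere on the shared core, would move the value beyond the scatter.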